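Replacing 6-methoxypyridin-2-yl with pyrimidin-4-yl

This account rests on a few compounds, and the source may have more. Where it says the series, first, only, none or still open, it means among the compounds named here.

For the measured compounds named here, in a physicochemical assay for solubility, using the shake flask method, measured as kinetic solubility, with a stated time of 20 h, at pH 2 (a higher number here means a more soluble compound, a lower number a less soluble compound), compound 1 `COc1cccc(Nc2cc3[nH]c(-c4cccc(C(F)(F)F)c4)nc3cn2)n1` gives 85000 nM as the only actual number so far. Compound 2 `COc1ccnc(Nc2cc3[nH]c(-c4cccc(C(F)(F)F)c4)nc3cn2)c1` gives < 5000 nM as a limit of the assay and not a number. Going by the values given here, the one measured step, with 4-methoxypyridin-2-yl in place of 6-methoxypyridin-2-yl on a nitrogen on an aromatic ring, is an at least 17-fold lower number from compound 1 to compound 2 (1.23 log units; beyond the scatter) and counts as large. Compound 3 `FC(F)(F)c1cccc(-c2nc3cnc(Nc4ccncn4)cc3[nH]2)c1` instead carries pyrimidin-4-yl in place of 6-methoxypyridin-2-yl on that nitrogen pyrimidin-4-yl in place of 6-methoxypyridin-2-yl on a nitrogen on an aromatic ring and keeps the shared core. Among the compounds with values here, only that one step bears on this change, and its entering group differs. Within the data shown here, with an at least 17-fold lower number from compound 1 to compound 2 (1.23 log units; beyond the scatter) as the sole guide, a lower number beyond the scatter is expected in this assay for compound 3, though probably a smaller drop. The expected change is a 4.3-fold lower number from compound 1 to compound 3 (0.63 log units; beyond the scatter) on this reasoning. The estimate for compound 3 is 20000 nM with an expected range from 5000 nM to 80000 nM as its likely span.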

Compound 3, solubility: 200000 nM
Compound 3: the middle estimate sits 10-fold (1.00 log units) below what was measured, and the stated range ends below it.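

In this assay, a change at this nitrogen on an aromatic ring need not lower the number: replacing 6-methoxypyridin-2-yl with pyrimidin-4-yl gives a 2.4-fold higher number from compound 1 to compound 3 (0.37 log units; beyond the scatter). The direction of the step therefore depends on the entering group, and exchanging 4-methoxypyridin-2-yl for pyrimidin-4-yl gives an at least 40-fold higher number from compound 2 to compound 3 (1.60 log units; beyond the scatter). Compound 2 has a limit of the assay and not a number, so this second step has only a lower bound on its size: the limit of < 5000 nM in this assay, at which 1 of the 3 values shown sits.

Pyrimidin-4-yl differs from 6-methoxypyridin-2-yl both in its ring hetero atoms and in lacking the methoxy group, and the compounds shown do not separate these two differences. They also leave open how an unsubstituted pyridin-2-yl, or a pyrimidin-4-yl carrying a methoxy group or an amine, would read in this assay.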